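Acetylating the hydroxyl of an already stable compound

The compounds below may be only part of what the source reports. "The series", "measured", "known", "first", "only" and "open" are said of these compounds alone.

Compound 1 `C[C@@H](O)[C@H]1C(=O)N2C3=C(S[C@@H]4CN[C@@H](C4)C(=O)Nc4cccc(c4)C(=O)OCOCOC3=O)[C@H](C)[C@H]12` was examined in a physicochemical assay for metabolic stability, read by LC-MS, in phosphate buffer, with a stated time of 3 h, at pH 7.4, tested at 50 uM; on this read-out lower numbers stand for a less stable compound and higher numbers for a more stable compound. In this assay compound 1 gives > 95%, which is a limit of the assay rather than a number. Two other compounds of the same series sit at the same point. In this assay compound 2 `CC(=O)OCOC(=O)C1=C(S[C@@H]2CN[C@H](C(=O)Nc3cccc(C(=O)OCOC(C)=O)c3)C2)[C@H](C)[C@@H]2[C@@H]([C@@H](C)O)C(=O)N12` gives > 95%, again a limit of the assay. In this assay compound 3 `COC(=O)C1=C(S[C@@H]2CN[C@H](C(=O)Nc3cccc(C(=O)OC)c3)C2)[C@H](C)[C@@H]2[C@@H]([C@@H](C)O)C(=O)N12` gives > 95%, also a limit of the assay. Within the data shown here, compound 1 therefore stands at the limit of > 95% in this assay, at which 3 of the 3 values shown sit, and no step between measured compounds is available from which a direction could be read.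

Compound 4 `CC(=O)O[C@H](C)[C@H]1C(=O)N2C3=C(S[C@@H]4CN[C@@H](C4)C(=O)Nc4cccc(c4)C(=O)OCOCOC3=O)[C@H](C)[C@H]12` has not yet been measured in this assay. It differs from compound 1 by acetyl in place of hydrogen on an oxygen on a saturated carbon; cut one bond further out, the change reads hydroxy to acetoxy, or 1-hydroxyethyl to 1-acetoxyethyl. With all three measured compounds at the limit, no movement beyond the scatter is expected. In this assay the expected step is a number no higher from compound 1 to compound 4 (the limit leaves the size open), essentially none. Compound 4 is expected to give 95% in this assay, between 85% and 100%, most likely again reported as a limit.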

Compound 4, percent of the compound remaining: > 95%
Compound 4 gave a limit, no number; the forecaster's own chance of this, stated with the estimate: 75%; the middle value sits exactly at the limit.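

Compound 1 and compound 4 both sit at a limit of this assay, so no step between them can be read: the limit of > 95% in this assay, at which 4 of the 4 values shown sit.

The compounds shown leave open whether acetyl in place of hydrogen on an oxygen on a saturated carbon changes the percent remaining at all.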